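The source may hold more compounds than are shown below. What is called first, only, known or untested is meant among the compounds shown, and "the series" means these compounds.

Working notes on the cytotoxicity series.

Compound 1 `O=C(O)c1cccc(-c2ccc(/C=C3\S/C(=N\c4ccccc4)N(c4ccc(F)cc4)C3=O)o2)c1`, compound 2 `O=C(O)c1cccc(-c2ccc(/C=C3\S/C(=N\c4ccccc4)N(c4ccc(F)cc4)C3=O)s2)c1` and compound 3 `O=C(O)c1cccc(-c2ccc(/C=C3\S/C(=N\c4ccccc4)N(c4ccc(F)cn4)C3=O)o2)c1` have been measured in an ADME assay on Vero cells (Chlorocebus sabaeus) for cytotoxicity; a lower number here means that less compound is tolerated, a higher number that more compound is tolerated. The difference between the core of compound 1 and the core of compound 2 is not broken down here. Compound 3 differs from compound 1 by 5-fluoropyridin-2-yl in place of 4-fluorophenyl on an amide-type nitrogen in a ring.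

In this assay compound 1 reaches only the limit of the assay, > 200000 nM. Compound 2 likewise reaches only the limit, > 200000 nM. Compound 3 also sits at the limit, > 200000 nM. The step that the two limits leave unreadable from compound 1 to compound 3 therefore cannot be sized, because of the limit of > 200000 nM in this assay, at which 3 of the 3 values shown sit; all three values shown are limits and none is a number.

Compound 4 `O=C(O)c1cccc(-c2ccc(/C=C3\S/C(=N\c4ccccc4)N(c4ccc(F)cn4)C3=O)s2)c1` has not yet been measured in this assay. It differs from compound 2 by 5-fluoropyridin-2-yl in place of 4-fluorophenyl on an amide-type nitrogen in a ring, the same change as from compound 1 to compound 3, at the same place in the ring. Since that change left compound 1 and compound 3 both at the limit, the expectation for the step of a number no higher from compound 2 to compound 4 (the limit leaves the size open) is that it too stays unreadable, with compound 4 most likely again reported only as a limit. The estimate for compound 4 in this assay is accordingly 200000 nM, within a band from 100000 nM to 400000 nM, resting on the three limit values of compound 1, compound 2 and compound 3 and on nothing beyond them.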

Compound 4, half-maximal cytotoxic concentration: > 200000 nM
Compound 4 was reported as a limit; the forecaster's own chance of this, stated with the estimate: 85%; the middle value lies on the limit itself.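

In this assay compound 4 gives > 200000 nM, which is a limit and not a number. No new step can be read from compound 2 to compound 4, and the size of the change to 5-fluoropyridin-2-yl stays unknown: the limit of > 200000 nM in this assay, at which 4 of the 4 values shown sit. The compounds shown leave open at what concentration any of them becomes cytotoxic in this assay, and whether the 4-fluorophenyl and 5-fluoropyridin-2-yl compounds differ at all.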